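Chloro Placement on an Aromatic Ring of a Fused Core

The source may hold more compounds than are shown below. What is called first, only, known or untested is meant among the compounds shown, and "the series" means these compounds.

Measured compounds:
Compound 1, `COC(=O)[C@@]1(C)CC[C@@H]2C3=C1CC[C@@H](C)[C@]3(C)C[C@@H]1c3ccccc3N[C@H]21`: 30000 nM
Compound 2, `COC(=O)[C@@]1(C)CC[C@@H]2C3=C1CC[C@@H](C)[C@]3(C)C[C@@H]1c3cc(Cl)ccc3N[C@H]21`: 38000 nM

In a functional assay on SW1573 cells (Homo sapiens) for inhibition, read by sulforhodamine B assay, with a stated time of 48 h (a higher number here means a weaker inhibitor of growth, a lower number a stronger inhibitor of growth), compound 1 gives 30000 nM. Compound 2 gives 38000 nM in this assay, and the two numbers lie within the scatter of each other, so compound 1 cannot be set apart from compound 2 on these data. Within the data shown here, the one measured step, a 1.3-fold higher number from compound 1 to compound 2 (0.10 log units; within the scatter), shows that a chloro group entering the aromatic ring at that place did nothing the assay could detect.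

Compound 3, `COC(=O)[C@@]1(C)CC[C@@H]2C3=C1CC[C@@H](C)[C@]3(C)C[C@@H]1c3cccc(Cl)c3N[C@H]21`, is not yet measured. Its change from compound 1 is chloro in place of hydrogen on an aromatic carbon. Among the measured compounds shown here, the only step that bears on it is a 1.3-fold higher number from compound 1 to compound 2 (0.10 log units; within the scatter), which stayed within the scatter. A similarly small step is therefore expected in this assay, with no direction beyond the scatter, because a 1.3-fold higher number from compound 1 to compound 2 (0.10 log units; within the scatter) showed none. Compound 3 is estimated at 33000 nM, within a range from 15000 nM to 70000 nM, meaning an expected step of a 1.1-fold higher number from compound 1 to compound 3 (0.04 log units; within the scatter).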

Compound 3, concentration for 50% growth inhibition: 49000 nM
Compound 3: the middle estimate sits 1.5-fold (0.17 log units) below what was measured; low and high end bracket the measured number.
By their numbers in this assay, from the lowest: compounds 1, 2 and 3 (each within the scatter of the next).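

Chloro in place of hydrogen on this aromatic carbon, ortho to a fused ring and meta to a fused ring, gives [ a 1.6-fold higher number from compound 1 to compound 3 (0.21 log units; within the scatter) ] in this assay. Compound 2 had shown such a tolerated swap at only one aromatic carbon, whereas compound 3 shows that a second carbon of the same ring also takes a chloro group with no change that can be told from the scatter. No further measurement bears on this result.

The compounds shown leave open whether a different group at this place, such as an amine or a carboxylic acid, would move the number beyond the scatter. They also leave open whether changes away from the aromatic ring, for example replacing the methyl ester with a carboxylic acid, would do so.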